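The source may report more compounds than this note shows. Statements on the series, on what has been measured and on what is new or still open speak of the compounds shown alone.

Of the compounds shown here, two have been measured in a functional assay on MCF7 cells (Homo sapiens) for inhibition, read by fluorescence, with a stated time of 72 h; on this read-out higher numbers stand for weaker inhibition of growth and lower numbers for stronger inhibition of growth. Compound 1 `CCCCCc1cc2nn(-c3ccccc3)cc2c(C)n1` carries a pentyl chain on its core and gives 17000 nM. Compound 2 `Cc1nc(-c2ccccc2)cc2nn(-c3ccccc3)cc12` carries a phenyl group at the same place and gives 11000 nM. Compound 2 thus has the lower of the two numbers, but the step of a 1.5-fold lower number from compound 1 to compound 2 (0.19 log units; within the scatter) stays within the scatter, so the two compounds cannot be told apart on these data.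

Compound 3 `CCCCc1cc2nn(-c3ccccc3)cc2c(C)n1` has not yet been measured. Compared with compound 2 it shows (butyl in place of phenyl on an aromatic carbon).

Going by the values given here, the only measured step that bears on this change is the one from pentyl to phenyl, a 1.5-fold lower number from compound 1 to compound 2 (0.19 log units; within the scatter), which was within the scatter. Going from phenyl to butyl undoes most of that change, leaving a chain one carbon shorter than in compound 1. Because of the small size of a 1.5-fold lower number from compound 1 to compound 2 (0.19 log units; within the scatter), no step beyond the scatter is expected in this assay, in either direction. The step that this estimate means, a 1.4-fold higher number from compound 2 to compound 3 (0.13 log units; within the scatter), is expected to stay within the scatter. Compound 3 is therefore expected to give about 15000 nM, within a range from 6000 nM to 40000 nM.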

Compound 3, concentration for 50% growth inhibition: 11100 nM
For compound 3 the middle estimate is 1.4-fold (0.13 log units) above the measured one; measured number inside the range.
By their numbers in this assay, from the lowest: compounds 2, 3 and 1 (each within the scatter of the next).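

In this assay, the step of a 1.0-fold higher number from compound 2 to compound 3 (0.00 log units; within the scatter) stays within the scatter, so butyl and phenyl on this aromatic carbon, next to the ring nitrogen, cannot be told apart, even though one is an open chain and the other a six-membered aromatic ring. The step of a 1.5-fold lower number from compound 1 to compound 3 (0.19 log units; within the scatter) is also within the scatter, so butyl and pentyl cannot be told apart either, and all three groups tried at this position now give numbers within the scatter of one another. No measurement is available that would explain this flat result, so it stands as an observation without a known cause.

From the compounds shown here alone, it remains open whether any group at this position can move the number beyond the scatter, and an amine, a carboxylic acid or a much longer chain would each test this in a different way. Also open, going by these compounds, is what the methyl group on the shared core contributes, as it is the same in all three compounds.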